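Lengthening the methoxy group of compound 2

The source may hold more compounds than are shown below. What is called first, only, known or untested is meant among the compounds shown, and "the series" means these compounds.

Compound 1 `CSc1ccc(C2=C(c3ccc(F)c(F)c3)C(=O)N3CCCC3C2)cc1` gives 100 nM
Compound 2 `COc1ccc(C2=C(c3ccc(SC)cc3)CC3CCCN3C2=O)cc1` gives 800 nM

In a functional assay on A498 cells (Homo sapiens) for cytotoxicity (on this read-out higher numbers stand for weaker inhibition of growth and lower numbers for stronger inhibition of growth), compound 2 (800 nM) has the higher of the two numbers, so it is the weaker growth inhibitor of the pair. Compound 3 `CSc1ccc(C2=C(c3ccc(OCC4CO4)cc3)C(=O)N3CCCC3C2)cc1` has oxiran-2-yl in place of hydrogen on a saturated chain carbon bound to an oxygen on an aromatic ring, which turns methoxy into (oxiran-2-yl)methoxy. For the measured compounds named here, only one measured step bears on this change: an 8.0-fold higher number from compound 1 to compound 2 (0.90 log units; beyond the scatter) when 4-methoxyphenyl replaces 3,4-difluorophenyl on a double-bonded ring carbon. That modest step shows that the group at this carbon can move the number, but no measurement tests the new group itself. Going by the values given here, a small shift toward a lower number is therefore expected, no larger than that step, and the direction remains uncertain. The expected change is a 2.0-fold lower number from compound 2 to compound 3 (0.30 log units; within the scatter) in this estimate. For compound 3 the estimated value is 400 nM (expected range 80 nM to 2000 nM).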

Compound 3, concentration for 50% growth inhibition: 500 nM
The estimate for compound 3 lay 1.3-fold (0.10 log units) below the measured number; measured number inside the range.
By their numbers in this assay, from the lowest: compound 1; then compounds 3 and 2 (each within the scatter of the next).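

In this assay, adding oxiran-2-yl on a saturated chain carbon bound to an oxygen on an aromatic ring gives a 1.6-fold lower number from compound 2 to compound 3 (0.20 log units; within the scatter), so methoxy and (oxiran-2-yl)methoxy cannot be told apart on this read-out. The earlier step showed only that exchanging a whole aryl group could move the number, whereas this step shows that the methoxy group can carry a three-membered ring with no change beyond the scatter. No measurement among these data explains this result.

The compounds shown leave open whether the ring itself matters or whether any group of similar length would do equally well, a question that a plain propoxy chain could help to answer. They also leave open how a basic amine at the end of this chain would behave.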